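This account rests on a few compounds, and the source may have more. Where it says the series, first, only, none or still open, it means among the compounds named here.

Two glycosides built on the same core have been tested in a functional assay on SK-MEL-2 cells (Homo sapiens) for cytotoxicity, read by sulforhodamine B assay; a higher number here means a weaker inhibitor, a lower number a stronger inhibitor. Compound 1 `COc1cc([C@H]2Oc3c(OC)cc(CCCO)cc3[C@@H]2CO[C@@H]2O[C@@H](C)[C@H](O)[C@@H](O)[C@H]2O)cc(OC)c1O` carries the 3,4,5-trihydroxy-6-methyloxan-2-yl sugar. In this assay compound 1 gives > 10000 nM, which is a limit of the assay and not a number. Compound 2 `COc1cc([C@H]2Oc3c(OC)cc(CCCO)cc3[C@@H]2CO[C@@H]2O[C@H](CO)[C@@H](O)[C@H](O)[C@H]2O)ccc1O` carries the 3,4,5-trihydroxy-6-(hydroxymethyl)oxan-2-yl sugar instead. In this assay compound 2 gives > 10000 nM, again only a limit. Compound 2 thus stands at the limit shared by both values shown, (the limit of > 10000 nM in this assay, at which 2 of the 2 values shown sit), and no difference between the two compounds can be read from them. Compound 3 `COc1cc([C@H]2Oc3c(OC)cc(CCCO)cc3[C@@H]2CO[C@@H]2O[C@@H](C)[C@H](O)[C@@H](O)[C@H]2O)ccc1O` differs from compound 2 by 3,4,5-trihydroxy-6-methyloxan-2-yl in place of 3,4,5-trihydroxy-6-(hydroxymethyl)oxan-2-yl on an oxygen on a saturated carbon. For the measured compounds named here, no measured step of this kind exists here, and since both measured compounds sit at the limit, no shift beyond the scatter is expected in this assay from this change. Compound 3 is therefore expected to give about 20000 nM in this assay, somewhere between 8000 nM and 60000 nM. The expected step that the limit leaves unreadable from compound 2 to compound 3 lies within the scatter.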

Compound 3, half-maximal inhibitory concentration: > 10000 nM
Compound 3: only a limit was reported; the forecaster's own chance of this, stated with the estimate: 85%; the middle value is on the limit's open side.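

No step can be read between compound 1, compound 2 and compound 3, because all three sit at the same limit: the limit of > 10000 nM in this assay, at which 3 of the 3 values shown sit. The compounds shown leave open whether the choice of sugar or the methoxy group on the aromatic carbon changes the cytotoxicity at all.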